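Removing the amino-amide side chain from compound 2

The source may hold more compounds than are shown below. What is called first, only, known or untested is meant among the compounds shown, and "the series" means these compounds.

Compound 2 `CCOc1ccccc1-c1ccc(-c2nc3cnccc3c(N[C@H](CC(C)C)C(N)=O)c2C#N)cc1` stands highest of the two numbers in a physicochemical assay for lipophilicity, read by HPLC, at pH 7.5 (a lower number here means a more polar compound, a higher number a more lipophilic compound), where compound 2 gives 3.4. Among the measured compounds shown here, compound 1 `CCOc1ccccc1-c1ccc(-c2nc3cnccc3c(C[C@H](C)C(=O)O)c2C#N)cc1` in this assay gives 2.2; the one measured step, a number 1.20 log units higher from compound 1 to compound 2 (beyond the scatter), exchanged one side chain for another rather than removing one. Compound 3 `CCOc1ccccc1-c1ccc(-c2nc3cnccc3cc2C#N)cc1` carries the change (hydrogen in place of (1-carbamoyl-3-methylbutyl)amino on an aromatic carbon). For the measured compounds named here, no measured step removes this group entirely, so the bearing of the measured step is indirect, and the step of a number 0.10 log units higher from compound 2 to compound 3 (within the scatter) is expected to stay within the scatter. Compound 3 is therefore estimated at 3.5, within 2.9 to 4.1.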

Compound 3, distribution coefficient: 3.8
The estimate for compound 3 lay 0.30 log units below the measured number; measured number inside the range.
By their numbers in this assay, from the lowest: compound 1; then compound 2; then compound 3.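

In this assay the position with hydrogen on the aromatic carbon ortho to a cyano group gives the highest number of the three: taking away the (1-carbamoyl-3-methylbutyl)amino group is a modest step, a number 0.40 log units higher from compound 2 to compound 3 (beyond the scatter), while taking away the 2-carboxypropyl group is a large one, a number 1.60 log units higher from compound 1 to compound 3 (beyond the scatter). Each side chain at this position therefore goes with a lower number than hydrogen, by different amounts. Nothing available explains this difference.

As far as these compounds go, whether a plain amino or methyl group here would stand closer to compound 3 remains open. So does how much of each gap belongs to the carbon chain rather than to the amide or the carboxylic acid.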